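A few compounds are considered here, and "the series" means these few. Any claim that something is new, unique, unknown or untested is made for them only; others in the source may bear on it.

Measured compounds:

compound 1, `COc1ccc(CNC(=O)CSc2nc3ccc(NC(=O)c4ccc(Cl)cc4)cc3s2)cc1`, 7400 nM
compound 2, `O=C(CSc1nc2ccc(NC(=O)CCl)cc2s1)NCc1ccccc1`, 1100 nM
compound 3, `CNC(=O)CSc1nc2ccc(NC(=O)CCl)cc2s1`, 1900 nM

In a functional assay on HepG2 cells (Homo sapiens) for cytotoxicity, read by MTT assay, with a stated time of 48 h (a higher number here means a weaker inhibitor, a lower number a stronger inhibitor), compound 2 gives 1100 nM, the lowest of the three numbers. Its nearest neighbour is compound 3, which gives 1900 nM in this assay; the two lie within the scatter, as the step of a 1.7-fold higher number from compound 2 to compound 3 (0.24 log units; within the scatter) shows. Compound 1 stands furthest away, at 7400 nM in this assay, beyond the scatter from compound 2.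

Compound 4, `O=C(CSc1nc2ccc(NC(=O)c3ccccc3)cc2s1)NCc1ccccc1`, differs from compound 2 in one place: phenyl in place of chloromethyl on a carbonyl carbon. Going by the values given here, no measured step matches this change. Among the compounds with values here, the one measured step, a 1.7-fold higher number from compound 2 to compound 3 (0.24 log units; within the scatter), concerns the other end of the molecule and gives no guidance here. Within the data shown here, what the data do offer is compound 1, the only compound with an aromatic group on this carbonyl carbon: it differs from compound 2 in two places, so no single step can be read, but its number is the highest of the three. On that basis compound 4 is expected to give a higher number than compound 2, a step of roughly a 5.5-fold higher number from compound 2 to compound 4 (0.74 log units; beyond the scatter), with considerable uncertainty. The estimate for compound 4 in this assay is 6000 nM, with a range from 2500 nM to 15000 nM.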

Compound 4, half-maximal inhibitory concentration: 34200 nM
Compound 4: middle estimate off by 5.7-fold (0.76 log units), on the low side; measured number outside the range, above it.
By their numbers in this assay, from the lowest: compounds 2 and 3 (each within the scatter of the next); then compound 1; then compound 4.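

In this assay, going by these compounds alone, the step of a 31-fold higher number from compound 2 to compound 4 (1.49 log units; beyond the scatter) gives the first reading of the group on this carbonyl carbon taken alone, as compound 1 carried an aromatic group there only together with a second difference from compound 2. Within the data shown here, it shows that the number responds strongly to the exchange of chloromethyl for phenyl at this position, whereas the only earlier single change, at the other end of the molecule, gave a 1.7-fold higher number from compound 2 to compound 3 (0.24 log units; within the scatter) and stayed within the scatter. Nothing among the data shown accounts for the size of this step.

The compounds shown leave open how much of the step goes with the loss of the chlorine and how much with the entry of the ring; none of them has a plain methyl, a longer chain such as ethyl or an aminomethyl group on this carbonyl carbon. They also leave open whether a chlorine or an amine on the phenyl of compound 4, with the rest of the molecule unchanged, would shift its number in this assay at all.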